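Amide nitrogen substituent change within the shared core

The source may hold more compounds than are shown below. What is called first, only, known or untested is meant among the compounds shown, and "the series" means these compounds.

Measured compounds in an assay for inhibition of Polyunsaturated fatty acid 5-lipoxygenase (Homo sapiens); on this read-out higher numbers stand for weaker inhibition and lower numbers for stronger inhibition:
compound 1 `CCCOc1cc(C)c2c(c1C)CC(C(C)C(=O)NCc1cccs1)CC2`: 3000 nM
compound 2 `COCCOc1cc(C)c2c(c1C)CC(C(C)C(=O)NC1CCCC1)CC2`: reported as a limit, > 10000 nM
compound 3 `COc1cc(C)c2c(c1C)CC(C(C)C(=O)NC(C)(C)C)CC2`: 4000 nM

Compound 3 holds the higher of the two numbers given, but its value in this assay lies within the scatter of the value of compound 1, so the two are not distinguished. For compound 2 the assay gives only a limit, not a number (the limit of > 10000 nM in this assay, at which 1 of the 3 values shown sits).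

Compound 4 `COc1cc(C)c2c(c1C)CC(C(C)C(=O)NCc1cccs1)CC2` has not yet been measured. It differs from compound 3 in one place: (thiophen-2-yl)methyl in place of tert-butyl on an amide-type nitrogen. Compound 1 carries the same (thiophen-2-yl)methyl amide on a core with a different ether group and gives 3000 nM, which sits within the scatter of compound 3. Going by the values given here, no measured pair isolates this amide change, so the expectation for compound 4 rests on compounds 1 and 3 alone. The expected step in this assay from compound 3 to compound 4 is a 1.3-fold lower number from compound 3 to compound 4 (0.12 log units; within the scatter), that is, no shift beyond the scatter. For compound 4 the estimate in this assay is 3000 nM, with a range from 1000 nM to 10000 nM.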

Compound 4, half-maximal inhibitory concentration: > 10000 nM
Compound 4 gave a limit, no number (the forecaster's own chance of this, stated with the estimate: 15%); middle value at least 3.3-fold (0.52 log units) from the limit.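

In this assay, the amide nitrogen substituent and the ether group can now each be read as a one-place change. With the ether group of compound 3 held, (thiophen-2-yl)methyl in place of tert-butyl on the amide-type nitrogen gives an at least 2.5-fold higher number from compound 3 to compound 4 (0.39 log units; beyond the scatter), and with the (thiophen-2-yl)methyl amide held, hydrogen in place of ethyl on the saturated chain carbon bound to the oxygen gives an at least 3.3-fold higher number from compound 1 to compound 4 (0.52 log units; beyond the scatter). Inhibition by this amide therefore depends on the ether group, and compound 4 is reported only as a limit, a value shared with compound 2: the limit of > 10000 nM in this assay, at which 2 of the 4 values shown sit.

Going by these compounds, the true size of both steps stays open, as does whether the ether change would give a similar step with the tert-butyl amide. Also open, on these data alone, is how a butyl ether, or a carboxylic acid or an amine on the amide nitrogen substituent, would read.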